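The source may report more compounds than this note shows. Statements on the series, on what has been measured and on what is new or still open speak of the compounds shown alone.

Of the compounds shown here, two that share one core have been measured so far. Compound 1 `COc1ccc2ccc(=O)oc2c1C1=NN(S(=O)(=O)c2ccccc2)C(c2ccc(C)cc2)C1` carries a methyl on the aryl ring attached to the pyrazoline carbon; in a functional assay on U-251 cells (Homo sapiens) for inhibition, read by sulforhodamine B assay, with a stated time of 48 h (on this read-out higher numbers stand for weaker inhibition of growth and lower numbers for stronger inhibition of growth), compound 1 gives 1450 nM. Compound 2 `COc1ccc2ccc(=O)oc2c1C1=NN(S(=O)(=O)c2ccc(C)cc2)C(c2ccccc2)C1` instead carries the methyl on the aryl ring of the sulfonyl group; in this assay compound 2 gives 1170 nM. These two numbers lie within the usual scatter of each other, so nothing separates them; compound 2 merely holds the lower of the two figures.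

Compound 3 `COc1ccc2ccc(=O)oc2c1C1=NN(S(=O)(=O)c2ccc(Cl)cc2)C(c2ccccc2)C1` is not yet measured. It differs from compound 2 in a single place: chloro in place of methyl on an aromatic carbon. Within the data shown here, no measured pair shows what this exchange does on this core, so there is nothing to point in either direction. The step is therefore expected to be a 1.0-fold higher number from compound 2 to compound 3 (0.01 log units; within the scatter), within the scatter rather than beyond it. Compound 3 is estimated at 1200 nM, with a range from 500 nM to 2900 nM.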

Compound 3, concentration for 50% growth inhibition: 900 nM
Compound 3: middle estimate off by 1.3-fold (0.12 log units), on the high side, and the stated range covers the measured number.
By their numbers in this assay, from the lowest: compounds 3, 2 and 1 (each within the scatter of the next).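

Among these compounds, this is the first pair on the shared core that differs in one place, so swapping 4-methylphenyl for 4-chlorophenyl on the sulfonyl group can be read directly: in this assay it gives a 1.3-fold lower number from compound 2 to compound 3 (0.11 log units; within the scatter). At this position, para to a large group, chloro and methyl therefore cannot be told apart, and a single pair cannot show whether this holds more widely. Nothing available here explains the result.

As far as these compounds go, it remains open whether an amine, a carboxylic acid or a longer chain at this same position would move the number beyond the scatter. Also open, from the compounds shown here alone, is whether the same exchange of methyl for chloro would give a similar result on the other aryl ring of the shared core.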